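The source may report more compounds than this note shows. Statements on the series, on what has been measured and on what is new or still open speak of the compounds shown alone.

Working notes on the series. The shared core is shown in compound 1 `CC(=O)Oc1ccccc1C(=O)O[C@H]1CO[C@H]2[C@@H]1OC[C@H]2OC(=O)c1ccccc1O`, which bears 2-hydroxyphenyl on a carbonyl carbon; compound 2 `CC(=O)Oc1ccccc1C(=O)O[C@H]1CO[C@H]2[C@@H]1OC[C@H]2OC(=O)c1snnc1C` carries 4-methyl-1,2,3-thiadiazol-5-yl there, and compound 3 `CCC(=O)O[C@@H]1CO[C@H]2[C@@H]1OC[C@@H]2OC(=O)c1ccccc1OC(C)=O` carries ethyl. In an ADME assay on a cell-free system (plasma, Homo sapiens) for metabolic stability, with Plasma (Rattus norvegicus) as the target, read by HPLC, at pH 7.4 (a lower number here means that the compound disappears faster, a higher number that the compound lasts longer), compound 1 gives 0.0825 h, compound 2 gives 0.0642 h and compound 3 gives 0.0608 h. On these numbers compound 2 stands between the other two, but every step among them lies within the scatter: a 1.3-fold lower number from compound 1 to compound 2 (0.11 log units; within the scatter), a 1.4-fold lower number from compound 1 to compound 3 (0.13 log units; within the scatter) and a 1.1-fold lower number from compound 2 to compound 3 (0.02 log units; within the scatter). Across the three groups tried at this carbonyl carbon, the half-life in this assay has not moved beyond the scatter.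

Compound 4 `CC(=O)Oc1ccccc1C(=O)O[C@H]1CO[C@H]2[C@@H]1OC[C@H]2OC(=O)C1CC1` is not yet measured. Its difference from compound 2 is cyclopropyl in place of 4-methyl-1,2,3-thiadiazol-5-yl on a carbonyl carbon. The step that bears most directly on it is a 1.1-fold lower number from compound 2 to compound 3 (0.02 log units; within the scatter), where ethyl took the place of the same 4-methyl-1,2,3-thiadiazol-5-yl group. Together with a 1.3-fold lower number from compound 1 to compound 2 (0.11 log units; within the scatter) and a 1.4-fold lower number from compound 1 to compound 3 (0.13 log units; within the scatter), this gives no ground to expect a step beyond the scatter in this assay for compound 4 in either direction. Compound 4 is therefore estimated at 0.065 h, with a range from 0.035 h to 0.12 h. The expected step of a 1.0-fold higher number from compound 2 to compound 4 (0.01 log units; within the scatter) is thus within the scatter.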

Compound 4, half-life: 0.0322 h
For compound 4 the middle estimate is 2.0-fold (0.31 log units) above the measured one; the measured number lies below the stated range.
By their numbers in this assay, from the lowest: compounds 4, 3, 2 and 1 (each within the scatter of the next, the first and the last beyond it).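

Going by these compounds alone, the first step at this carbonyl carbon to pass the scatter in this assay is a 2.6-fold lower number from compound 1 to compound 4 (0.41 log units; beyond the scatter), so the half-life does respond to the group placed here, though only modestly and, so far, only in this one pair. Cyclopropyl cannot be separated from the other two smaller replacements, given a 2.0-fold lower number from compound 2 to compound 4 (0.30 log units; within the scatter) and a 1.9-fold lower number from compound 3 to compound 4 (0.28 log units; within the scatter), so the series shows one pair at the ends of its range and no stepwise order among the groups. No measurement in hand bears on what lies behind these steps, and the loss of the hetero atoms in the change from 4-methyl-1,2,3-thiadiazol-5-yl to cyclopropyl can be linked to no effect.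

The compounds shown leave open whether the ring in cyclopropyl matters at all, since ethyl is the only open-chain group here and an isopropyl group or a cyclobutyl ring would be needed to read that. They also leave open whether a longer chain, an amine or a carboxylic acid on this carbonyl carbon would move the half-life further than the range seen so far.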